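The source may hold more compounds than are shown below. What is called first, only, known or untested is meant among the compounds shown, and "the series" means these compounds.

Of the compounds shown here, three have already been measured in an in vitro functional assay on 1321-N1 cells for agonist activity at P2Y purinoceptor 2 (Homo sapiens), read by scintillation proximity assay and inositol phosphate accumulation; on this read-out lower numbers stand for an effect already at smaller amounts and higher numbers for an effect only at larger amounts of compound. Compound 1 `O=c1[nH]c(=S)ccn1[C@@H]1O[C@H](COP(=O)(O)O)[C@@H](O)[C@H]1O` gives only a limit of the assay, > 100000 nM. Compound 2 `CSc1nc(=O)ccn1[C@@H]1O[C@H](COP(=O)(O)OP(=O)(O)O)[C@@H](O)[C@H]1O` gives 523 nM. Compound 3 `CNc1nc(=O)ccn1[C@@H]1O[C@H](COP(=O)(O)O)[C@@H](O)[C@H]1O` likewise gives only a limit, > 100000 nM. That places compound 3 at the limit of > 100000 nM in this assay, at which 2 of the 3 values shown sit. Compound 4 `O=c1ccn([C@@H]2O[C@H](COP(=O)(O)O)[C@@H](O)[C@H]2O)c(SCCc2ccccc2)n1` has not been measured; it differs from compound 3 by phenethylsulfanyl in place of methylamino on an aromatic carbon. For the measured compounds named here, no pair of measured compounds differing in a single place is available, so the size of such a change cannot be read from earlier data. The expected step from compound 3 to compound 4 in this assay is a step that the limit leaves unreadable from compound 3 to compound 4, which is not expected to reach beyond the scatter. Compound 4 is therefore estimated at 120000 nM, within a range from 15000 nM to 1000000 nM, and it may again be reported only as a limit.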

Compound 4, half-maximal effective concentration: 1300 nM
The estimate for compound 4 lay 92-fold (1.97 log units) above the measured number; measured number below the stated range.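

In this assay, phenethylsulfanyl in place of methylamino on the aromatic carbon between two ring nitrogen atoms brings an at least 76-fold lower number from compound 3 to compound 4 (1.88 log units; beyond the scatter). The group on this carbon alone can therefore decide whether the assay yields a number at all. The true size of the step cannot be read because compound 3 sits at a limit: the limit of > 100000 nM in this assay, at which 2 of the 4 values shown sit.

The compounds shown do not separate the contributions of the sulfur, the chain and the aromatic ring. Going by these compounds, how phenethylamino or a simple propylsulfanyl chain on this carbon would read in this assay remains open.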